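This account rests on a few compounds, and the source may have more. Where it says the series, first, only, none or still open, it means among the compounds named here.

Measured so far:
compound 1 `COc1cc(/C=C/C(=O)O)ccc1OC(=O)c1nc(C)c(C)nc1C` – 55.4%
compound 2 `CCOC(=O)/C=C/c1cc(OC)c(OC(=O)c2nc(C)c(C)nc2C)c(OC)c1` – -47%

In a functional assay on EA.hy 926 cells (Homo sapiens) for cytotoxicity, read by MTT assay, with stated times of 24 h and 12 h, tested at 100 uM (on this read-out higher numbers stand for a stronger effect at the one concentration tested and lower numbers for a weaker effect), compound 1 gives 55.4%, and compound 2 gives -47%, the lowest of the two numbers, a gap from compound 1 that lies beyond the scatter. Compound 3 `CCOC(=O)/C=C/c1ccc(OC(=O)c2nc(C)c(C)nc2C)c(OC)c1` is not yet measured. It differs from compound 2 in one place: hydrogen in place of methoxy on an aromatic carbon. Among the measured compounds shown here, no step between measured compounds follows this same change, so the expectation rests only on the two values shown. Because compound 1, which carries a single methoxy, gives 55.4%, the step of a number 57 percentage points higher from compound 2 to compound 3 (beyond the scatter) is expected to be upward and beyond the scatter. Compound 3 is therefore estimated at 10%, within a range of -40% to 60%.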

Compound 3, a percentage reported as activity, at one concentration (the size of the read-out at that concentration, not a potency): 71.6%
Estimate against measurement, compound 3: 61.6 percentage points below; the whole stated range lies below it.
By their numbers in this assay, from the lowest: compound 2; then compound 1; then compound 3.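

In this assay, hydrogen in place of methoxy on this aromatic carbon gives a number 118.6 percentage points higher from compound 2 to compound 3 (beyond the scatter) and takes the reading from negative to positive, so this single position weighs heavily. Ethyl in place of hydrogen on an oxygen next to a carbonyl group gives a number 16.2 percentage points higher from compound 1 to compound 3 (beyond the scatter) as a modest step by comparison. No measurement shown explains either step.

From the compounds shown here alone, whether a chlorine atom or an amine on this aromatic carbon would read closer to compound 2 or compound 3 stays open. So does the effect of a longer chain in place of ethyl.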